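A few compounds are considered here, and "the series" means these few. Any claim that something is new, unique, unknown or untested is made for them only; others in the source may bear on it.

Measured so far in a physicochemical assay for lipophilicity, read by HPLC, at pH 7.4; on this read-out lower numbers stand for lower lipophilicity and higher numbers for higher lipophilicity:
- compound 1 `O=C(O)CCn1c(=O)oc2cc(OCc3ccccc3)c(Cl)cc21`: 2.71
- compound 2 `C[C@@H](Oc1cc2c(cc1Cl)N(CCC(=O)O)C(=O)CO2)c1ccccn1`: 1.56

Of the two numbers, compound 1 stands highest; its nearest neighbour, compound 2, lies lower by a gap that is beyond the usual scatter of this assay. Going by the values given here, no pair of measured compounds differing in a single place has been recorded, so no measured step is available to calibrate the change below.

Compound 3 `CCc1cc2oc(=O)n(CCC(=O)O)c2cc1Cl` is not yet measured. Against compound 1 the difference is ethyl in place of benzyloxy on an aromatic carbon, the new group sitting on an aromatic carbon ortho to a chloro group of the shared core. The step from compound 1 to compound 3 is expected to be a moderate decrease, beyond the scatter, estimated as a number 0.61 log units lower from compound 1 to compound 3 (beyond the scatter). For compound 3 the value in this assay is therefore estimated at 2.1, with a likely range from 1.6 to 2.6.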

Compound 3, distribution coefficient: 1.94
Compound 3: the middle estimate sits 0.16 log units above what was measured; the range from low to high includes it.
By their numbers in this assay, from the lowest: compound 2; then compound 3; then compound 1.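

Going by these compounds alone, at this position, on an aromatic carbon ortho to a chloro group, ethyl in place of benzyloxy in this assay gives a number 0.77 log units lower from compound 1 to compound 3 (beyond the scatter), the only measured step so far between compounds that differ in one place. This step gives the series its first calibration at this position: the change takes out 8 heavy atoms, including a six-membered aromatic ring of carbon only and a hydrogen-bond acceptor, and puts in 2 heavy atoms, with no net charge on either group. One step cannot separate the contributions of the ring, the oxygen and the heavy-atom count, and no measurement bearing on the cause of the step is available.

On these data alone, how an ethoxy group or a simple amine at this position would read remains open. Also open, as far as these compounds go, is whether the same change on the core of compound 2 would give a step of similar size.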